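Aryl piperazine series: trifluoromethyl to fluoro step

The source may report more compounds than this note shows. Statements on the series, on what has been measured and on what is new or still open speak of the compounds shown alone.

Of the compounds shown here, two on the shared core have been measured. Compound 1 `CCCc1nc(-c2ccccc2)c(CNCCN2CCN(c3cccc(C(F)(F)F)c3)CC2)o1` carries a 3-(trifluoromethyl)phenyl; in an assay on HEK293 cells for inhibition of Voltage-dependent T-type calcium channel subunit alpha-1G (Homo sapiens), read by patch clamp (on this read-out higher numbers stand for weaker inhibition and lower numbers for stronger inhibition), compound 1 gives 1940 nM. Compound 2 `CCCc1nc(-c2ccccc2)c(CNCCN2CCN(C(c3ccccc3)c3ccccc3)CC2)o1`, built on the same core, in this assay gives 7470 nM. Compound 1 therefore stands at the lower of the two numbers, and the gap to compound 2 lies beyond the scatter. Compound 3 `CCCc1nc(-c2ccccc2)c(CNCCN2CCN(c3cccc(F)c3)CC2)o1` is not yet measured. It differs from compound 1 by fluoro in place of trifluoromethyl on an aromatic carbon. Within the data shown here, no measured pair shows this change, so no measured step can be read across. The expectation is a small loss, with the step from compound 1 to compound 3 estimated at a 1.8-fold higher number from compound 1 to compound 3 (0.26 log units; within the scatter), close to the edge of the scatter rather than clearly beyond it. Compound 3 is estimated at 3500 nM in this assay, with a range from 1200 nM to 10000 nM.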

Compound 3, half-maximal inhibitory concentration: 3350 nM
Beside the measured number, compound 3's estimate is 1.0-fold (0.02 log units) above it; the measured number falls inside the stated range.
By their numbers in this assay, from the lowest: compounds 1 and 3 (each within the scatter of the next); then compound 2.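

In this assay, among these compounds, fluoro in place of trifluoromethyl gives a 1.7-fold higher number from compound 1 to compound 3 (0.24 log units; within the scatter) and this is the first measured step at this aromatic carbon. Four heavy atoms leave and one enters, yet the two values stay within the usual scatter of each other, so this read-out does not separate 3-(trifluoromethyl)phenyl from 3-fluorophenyl. Nothing on hand accounts for this result.

Going by these compounds, it remains open how a methoxy, a nitrile or an amine on this same aromatic carbon would read, and how a plain phenyl with no such group would compare. The compounds shown also leave open whether fluoro in place of trifluoromethyl would give a similar step on other aromatic carbons of this ring.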